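The compounds below may be only part of what the source reports. "The series", "measured", "known", "first", "only" and "open" are said of these compounds alone.

In a functional assay on HeLa cells (Homo sapiens) for inhibition, read by MTT assay, with a stated time of 24 h (on this read-out lower numbers stand for stronger inhibition and higher numbers for weaker inhibition), compound 2 `Cc1ccc(-c2cc(COC3(C(F)(F)F)Oc4ccccc4C=C3C(=O)O)on2)cc1` gives 33400 nM. Compound 3 `CCOC(=O)C1=Cc2ccccc2OC1(OCc1cn(CC(=O)Nc2ccc(OC)cc2)nn1)C(F)(F)F` gives 31900 nM in this assay, a number within the scatter of compound 2, so no order between these two can be read. Compound 1 `CCOC(=O)C1=Cc2ccccc2OC1(OCc1cc(-c2ccc(C)cc2)no1)C(F)(F)F` reaches only the limit > 150000 nM in this assay. Going by the values given here, the single measured step, an at least 4.4-fold lower number from compound 1 to compound 2 (0.65 log units; beyond the scatter), starts from that limit of > 150000 nM in this assay, at which 1 of the 3 values shown sits, and so sets a lower bound on its size only. Compound 4 `O=C(O)C1=Cc2ccccc2OC1(OCc1cc(-c2ccc3ccccc3c2)no1)C(F)(F)F` differs from compound 2 by naphthalen-2-yl in place of 4-methylphenyl on an aromatic carbon. Among the compounds with values here, no measured step touches this position, so nothing bears on it directly, and the expected change in this assay is none beyond the scatter. Compound 4 is therefore estimated at 30000 nM in this assay, within 10000 nM to 100000 nM, with the expected step of a 1.1-fold lower number from compound 2 to compound 4 (0.05 log units; within the scatter).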

Compound 4, half-maximal inhibitory concentration: > 150000 nM
Compound 4 ended at the assay's limit; the forecaster's own chance of this, stated with the estimate: 15%; at least 5.0-fold (0.69 log units) between middle value and limit.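

In this assay the aromatic carbon next to the ring nitrogen proves sensitive to its substituent: naphthalen-2-yl in place of 4-methylphenyl gives an at least 4.4-fold higher number from compound 2 to compound 4 (0.65 log units; beyond the scatter) and fixes only a lower bound on the size of the change. Compound 4 stands at a limit of the assay, not at a number: the limit of > 150000 nM in this assay, at which 2 of the 4 values shown sit. Compound 4 keeps the carboxylic acid of compound 2, so the acid alone does not secure a reading under the limit.

Still open, on these data alone, is whether the second aromatic ring or the loss of the methyl carries the step. The compounds shown do not tell how a plain phenyl or a 4-chlorophenyl group would read at this position.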